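A few compounds are considered here, and "the series" means these few. Any claim that something is new, unique, unknown or untested is made for them only; others in the source may bear on it.

Compound 1, `Clc1ncc(OCC2CCCN2)cc1/C=C/c1ccccn1`, gives 0.331 nM in an assay for binding affinity to Neuronal acetylcholine receptor; alpha4/beta2 (Rattus norvegicus); a lower number here means a stronger inhibitor, a higher number a weaker inhibitor. Compound 2, `CN1CCCC1COc1cnc(Cl)c(/C=C/c2ccccn2)c1`, differs from it by methyl in place of hydrogen on an amine nitrogen in a ring. In this assay compound 2 gives 0.265 nM, and this change gave a 1.2-fold lower number from compound 1 to compound 2 (0.10 log units; within the scatter). Compound 3, `Clc1ncc(OCC2CCN2)cc1/C=C/c1ccncc1`, gives 0.009 nM in this assay; the difference between its core and the core of compound 1 is not broken down here, but its number is the lowest of the three, and its steps to compound 1 and compound 2 are both beyond the scatter. Compound 4, `CN1CCC1COc1cnc(Cl)c(/C=C/c2ccncc2)c1`, differs from compound 3 by methyl in place of hydrogen on an amine nitrogen in a ring. This is the same kind of change as from compound 1 to compound 2, though there the place was a five-membered non-aromatic ring with 1 nitrogen and here it is a four-membered one. Since the earlier step, a 1.2-fold lower number from compound 1 to compound 2 (0.10 log units; within the scatter), stayed within the scatter, compound 4 is expected to show a 1.1-fold lower number from compound 3 to compound 4 (0.05 log units; within the scatter). Compound 4 is therefore estimated at 0.008 nM, within 0.003 nM to 0.025 nM.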

Compound 4, inhibition constant: 0.072 nM
Compound 4: the middle estimate sits 9.0-fold (0.95 log units) below what was measured; measured number above the stated range.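

In this assay, methyl in place of hydrogen on an amine nitrogen in a ring gave an 8.0-fold higher number from compound 3 to compound 4 (0.90 log units; beyond the scatter). The size of this step did not carry over from one core to the other: the same change on two cores in this assay, a 1.2-fold lower number (0.10 log units; within the scatter) from compound 1 to compound 2 and an 8.0-fold higher number (0.90 log units; beyond the scatter) from compound 3 to compound 4, 10-fold (1.00 log units) apart, beyond the scatter of two such steps This shows that, across these two pairs, the result of the change depended on the core, but it does not show which difference between the cores matters, as they differ in more than the ring bearing the nitrogen, and two pairs establish no general rule.

The compounds shown leave open whether an ethyl group or a longer chain on the same nitrogen would follow the methyl steps on either core.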